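Topoisomerase inhibition: thiophene in place of pyridine on the core

The source may hold more compounds than are shown below. What is called first, only, known or untested is meant among the compounds shown, and "the series" means these compounds.

Two members of the series have been measured in an assay on isolated protein for inhibition of DNA topoisomerase 1 (Homo sapiens), with a stated time of 30 min, tested at 100 uM; on this read-out lower numbers stand for a weaker effect and higher numbers for a stronger effect at the one concentration tested. Compound 1 `Oc1cccc(-c2cc(-c3ccncc3)nc(-c3ccccc3Cl)c2)c1` gives 0%, the lowest of the two numbers, and compound 2 `Oc1ccc(-c2cc(-c3cccs3)nc(-c3ccccc3Cl)c2)cc1` gives 2.2%; the gap between them lies within the scatter, so neither can be placed above the other on this read-out. Both values show essentially no measurable inhibition at the concentration tested.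

Compound 3 `Oc1cccc(-c2cc(-c3ccsc3)nc(-c3ccccc3Cl)c2)c1` has not yet been measured in this assay. It departs from compound 1 in one place: thiophen-3-yl in place of pyridin-4-yl on an aromatic carbon. Compound 2 already carries a thiophene ring on the shared core and gives a number indistinguishable from compound 1, which is the only indication available on what a sulfur-containing five-membered ring does here. Within the data shown here, no step between measured compounds can be drawn from these two values.

On that basis no movement beyond the scatter is expected from compound 1 to compound 3; the step is estimated as a number 3 percentage points higher from compound 1 to compound 3 (within the scatter). For compound 3 the expected value in this assay is 3%, with a range from 0% to 15%.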

Compound 3, a percentage reported as inhibition, at one concentration (the size of the read-out at that concentration, not a potency): 0%
Estimate against measurement, compound 3: 3 percentage points above, within the range that was stated.
By their numbers in this assay, from the lowest: compounds 1, 3 and 2 (each within the scatter of the next).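

Thiophen-3-yl in place of pyridin-4-yl on the aromatic carbon next to the ring nitrogen gives, in this assay, no change at the digits printed from compound 1 to compound 3 (within the scatter); this is the first one-place comparison at this position, and exchanging the six-membered ring for the five-membered ring leaves the read-out unmoved. With compound 1 at 0% and compound 3 at 0%, both ends of the step sit at the bottom of the read-out, so the step shows only that neither of these two rings gives measurable inhibition at the one concentration tested, and it cannot show whether the two rings would differ on a core that has some effect. Nothing available bears on why the exchange changes nothing.

From the compounds shown here alone, what stays open is whether any group at this position can raise the read-out at all, for instance an aminomethyl group, a carboxylic acid or a longer alkyl chain in place of the ring. Going by these compounds, it is equally open whether the flat result belongs to this position or to the shared core as a whole, which a change such as a methoxy group in place of the hydroxyl on the 3-hydroxyphenyl group would begin to address.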